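The source may report more compounds than this note shows. Statements on the series, on what has been measured and on what is new or still open speak of the compounds shown alone.

Compound 1 `NC(=O)N1CCN(C(=S)SCc2cn(Cc3ccc(F)cc3)nn2)CC1` pairs a carbamoyl group on one end of the shared core with a 4-fluorobenzyl group on the other. In a functional assay on MCF7 cells (Homo sapiens) for cytotoxicity, read by MTT assay, with a stated time of 72 h (a higher number here means a weaker inhibitor, a lower number a stronger inhibitor), compound 1 gives 22100 nM. Compound 2 `CCNC(=O)N1CCN(C(=S)SCc2cn(Cc3ccc(F)cc3)nn2)CC1` differs from compound 1 by ethyl in place of hydrogen on an amide-type nitrogen, and in this assay compound 2 gives 3660 nM, so that a 6.0-fold lower number from compound 1 to compound 2 (0.78 log units; beyond the scatter). Compound 3 `Cc1ccc(Cn2cc(CSC(=S)N3CCN(C(N)=O)CC3)nn2)cc1` differs from compound 1 by methyl in place of fluoro on an aromatic carbon. For compound 3 this assay reports only a limit, > 128000 nM, which is the limit of > 128000 nM in this assay, at which 1 of the 3 values shown sits. From this limit it follows that an at least 5.7-fold higher number from compound 1 to compound 3 (0.76 log units; beyond the scatter).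

Compound 4 `CCNC(=O)N1CCN(C(=S)SCc2cn(Cc3ccc(C)cc3)nn2)CC1` has not yet been measured. It differs from compound 3 by ethyl in place of hydrogen on an amide-type nitrogen; the place is the same word for word as between compound 1 and compound 2, so this is the same change, now made on the other core, whose difference from the first is given by methyl in place of fluoro on an aromatic carbon. Resting on that single earlier step, the expectation is that an at least 2.8-fold lower number from compound 3 to compound 4 (0.45 log units; beyond the scatter), with added uncertainty since compound 3 shows only a limit. Compound 4 is therefore estimated at 45000 nM, likely between 12000 nM and 200000 nM.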

Compound 4, half-maximal inhibitory concentration: > 128000 nM
Compound 4 gave a limit, no number (the forecaster's own chance of this, stated with the estimate: 35%); middle value at least 2.8-fold (0.45 log units) away from the limit.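

With the ethyl group in place on the amide-type nitrogen, methyl in place of fluoro on an aromatic carbon gives an at least 34-fold higher number from compound 2 to compound 4 (1.54 log units; beyond the scatter), a large step, and in this assay it points the same way as the same change made without the ethyl group: the same change on two cores in this assay, an at least 5.7-fold higher number (0.76 log units; beyond the scatter) from compound 1 to compound 3 and an at least 34-fold higher number (1.54 log units; beyond the scatter) from compound 2 to compound 4; the limit leaves it open whether they differ

Compound 4 reads > 128000 nM, which is a limit of the assay and not a number. The ethyl step that lowered the number among the fluoro compounds cannot be read among the methyl compounds, so these data neither confirm nor rule out that it carries over, since compound 3 and compound 4 both rest on the limit: the limit of > 128000 nM in this assay, at which 2 of the 4 values shown sit.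

Going by these compounds, what remains open is how large the ethyl step is on the methyl core, and whether it exists there at all. Also open, on these data alone, is how a chloro group on that aromatic carbon, or a longer chain such as propyl on the amide-type nitrogen, would read in this assay.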